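The source may report more compounds than this note shows. Statements on the series, on what has been measured and on what is new or still open speak of the compounds shown alone.

Measured compounds:
compound 1 `CC1=C(C(=O)OC(C)(C)C)C(c2ccsc2)NC(=O)N1` — 47%
compound 2 `CCNC(=O)C1=C(C)NC(=O)NC1c1ccsc1` — 1%
compound 3 `CCSC(=O)C1=C(C)NC(=O)NC1c1ccoc1` — 1%

All three were run in an assay on membranes from HEK293 cells for displacement of a labelled ligand from adenosine receptor A2b (Homo sapiens), read by scintillation counting, with a stated time of 30 min, tested at 1 uM; a higher number here means more inhibition at the concentration tested (going by the name of the read-out), a lower number less inhibition. Compound 3 stands level with compound 2 at the digits read, the two of them together the lowest of the three numbers; compound 1 lies well above both. Within the data shown here, the only single-place step measured is a number 46 percentage points lower from compound 1 to compound 2 (beyond the scatter), which concerns the group on the carbonyl carbon, with the thiophen-3-yl ring held the same.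

Compound 4 `CCSC(=O)C1=C(C)NC(=O)NC1c1ccsc1` is the next one to be measured. It differs from compound 3 by thiophen-3-yl in place of furan-3-yl on a saturated ring carbon. Among the measured compounds shown here, no measured pair covers this change: compound 1 and compound 2 both carry thiophen-3-yl and compound 3 alone carries furan-3-yl, with a different group on the carbonyl carbon in each case, so no step in the set isolates the ring swap. The large move in a number 46 percentage points lower from compound 1 to compound 2 (beyond the scatter) came from the carbonyl side, which compound 4 shares with compound 3. Compound 4 is therefore expected to show at most a small step, a number 5 percentage points higher from compound 3 to compound 4 (within the scatter), within or near the scatter. Compound 4 is estimated at 6%, in the range -8% to 30%.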

Compound 4, a percentage reported as inhibition, at one concentration (the size of the read-out at that concentration, not a potency): 17%
Beside the measured number, compound 4's estimate is 11 percentage points below it, and the stated range covers the measured number.
By their numbers in this assay, from the lowest: compounds 2 and 3 (each within the scatter of the next); then compound 4; then compound 1.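

With the ethylsulfanyl carbonyl held the same, the ring on the saturated ring carbon can now be read on its own in this assay: a number 16 percentage points higher from compound 3 to compound 4 (beyond the scatter) for thiophen-3-yl in place of furan-3-yl. With thiophen-3-yl held the same, the group on the carbonyl carbon now has three measured points, with a number 16 percentage points higher from compound 2 to compound 4 (beyond the scatter) for ethylsulfanyl in place of ethylamino and a number 30 percentage points lower from compound 1 to compound 4 (beyond the scatter) for ethylsulfanyl in place of tert-butoxy, which places ethylsulfanyl in the middle of the three. No measurement of any property accompanies these steps, and their origin stays unexplained.

Furan-3-yl appears only with ethylsulfanyl, so whether the ring step carries over to tert-butoxy or ethylamino on the carbonyl stays open. Also open, as far as these compounds go, is how a phenyl ring on the saturated ring carbon, or a longer chain such as propylsulfanyl on the carbonyl carbon, would read.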